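This account rests on a few compounds, and the source may have more. Where it says the series, first, only, none or still open, it means among the compounds named here.

Working notes on the series. Among the measured compounds shown here, in a functional assay on HT-29 cells (Homo sapiens) for cytotoxicity, read by MTT assay, with a stated time of 72 h (on this read-out lower numbers stand for stronger inhibition and higher numbers for weaker inhibition), compound 1 `COc1ccc(C(=O)c2cc(OC)c(OC)c(OC)c2)cc1N` gives 50 nM, the lowest of the three numbers measured so far; both other compounds sit beyond the scatter from it. Compound 2 `COc1ccc(C(=O)c2cc(OC)c(OC)c(OC)c2)cc1NC(=O)/C=C/c1ccc(OC)c(OC)c1` gives 2500 nM in this assay, and compound 3 `COc1cccc(/C=C/C(=O)Nc2cc(C(=O)c3cc(OC)c(OC)c(OC)c3)ccc2OC)c1` gives 1900 nM. For the measured compounds named here, the one single-point step measured, a 1.3-fold lower number from compound 2 to compound 3 (0.12 log units; within the scatter), is too small to read as a change, so the two acylated compounds are treated as one level.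

Compound 4 `COc1ccc(C(=O)c2cc(OC)c(OC)c(OC)c2)cc1NC(=O)/C=C/c1ccc(F)cc1` differs from compound 1 by (2-(4-fluorophenyl)ethenyl)carbonyl in place of hydrogen on a nitrogen on an aromatic ring. Going by the values given here, no single-point step from compound 1 to compound 2 or to compound 3 is recorded, but what their values show is that replacing the free amine hydrogen of compound 1 with a cinnamoyl-type amide costs potency by a margin beyond the scatter in this assay, and that exchanging methoxy for hydrogen on the added aryl ring leaves that level essentially unchanged. The fluorine of compound 4 is a further aryl substituent of the same kind, so a loss of similar size is expected rather than a return toward compound 1. Compound 4 is therefore expected at 2000 nM, with a range from 700 nM to 6000 nM. That amounts to an expected step of a 40-fold higher number from compound 1 to compound 4 (1.60 log units; beyond the scatter).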

Compound 4, half-maximal inhibitory concentration: 1800 nM
Estimate against measurement, compound 4: 1.1-fold (0.05 log units) above; the measured number falls inside the stated range.
By their numbers in this assay, from the lowest: compound 1; then compounds 4, 3 and 2 (each within the scatter of the next).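

Among the compounds shown here, the first direct step on this nitrogen, in this assay, is a 36-fold higher number from compound 1 to compound 4 (1.56 log units; beyond the scatter), so placing (2-(4-fluorophenyl)ethenyl)carbonyl in place of hydrogen on a nitrogen on an aromatic ring carries a large loss, and the loss is now a measured step and not a reading from separate values. The aryl end of the added group now spans a fluorine as well as methoxy groups, with a 1.1-fold lower number from compound 3 to compound 4 (0.02 log units; within the scatter) and a 1.4-fold lower number from compound 2 to compound 4 (0.14 log units; within the scatter), both within the scatter, so 4-fluorophenyl, 3-methoxyphenyl and 3,4-dimethoxyphenyl at this chain carbon give one level across compounds 2, 3 and 4. No measurement is available that bears on the reason for the loss on acylation or for the flat response at the aryl end.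

Still open, from the compounds shown here alone, is whether the loss comes with the amide carbonyl alone or needs the double-bonded chain and the aryl ring as well, a question that a plain acetyl group on the same nitrogen would address. Also open, going by these compounds, is whether a carboxylic acid or an amine on that aryl ring would stay at the same level as compounds 2, 3 and 4.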